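Thiophene for furan on the carbonyl

This account rests on a few compounds, and the source may have more. Where it says the series, first, only, none or still open, it means among the compounds named here.

In a functional assay on MDA-MB-468 cells (Homo sapiens) for inhibition, read by CCK-8 assay and cell counting, with a stated time of 2 days (a higher number here means a weaker inhibitor, a lower number a stronger inhibitor), compound 2 (`O=C(/C=C/c1ccc(OCC(O)CCl)cc1)c1ccco1`) gives 9530 nM and compound 1 (`O=C(/C=C/c1ccc(OCC2CO2)cc1)c1cccs1`) gives 6300 nM. For the measured compounds named here, these two values lie within the usual scatter of each other, so compound 2 stands level with the only other compound measured so far.

Compound 3 (`O=C(/C=C/c1ccc(OCC(O)CCl)cc1)c1cccs1`) carries thiophen-2-yl in place of furan-2-yl on a carbonyl carbon. Going by the values given here, no two measured compounds differ in one place only, so the data give no direct size for this change. In this assay no step beyond the scatter is expected. Among the compounds with values here, the only guide is that compound 1 at 6300 nM and compound 2 at 9530 nM sit within the scatter of each other. The estimated change is a 1.3-fold lower number from compound 2 to compound 3 (0.10 log units; within the scatter). Compound 3 is expected at 7500 nM, with an estimated range of 3500 nM to 16000 nM.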

Compound 3, half-maximal inhibitory concentration: 7750 nM
The estimate for compound 3 lay 1.0-fold (0.01 log units) below the measured number; measured number inside the range.
By their numbers in this assay, from the lowest: compounds 1, 3 and 2 (each within the scatter of the next).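

In this assay, for the compounds shown here, the step of a 1.2-fold lower number from compound 2 to compound 3 (0.09 log units; within the scatter) for thiophen-2-yl in place of furan-2-yl on a carbonyl carbon gives the first direct reading at this position: the two rings stand level here. The step of a 1.2-fold higher number from compound 1 to compound 3 (0.09 log units; within the scatter) for 2-chloro-1-hydroxyethyl in place of oxiran-2-yl on a saturated chain carbon bound to an oxygen on an aromatic ring gives the same reading for the chain, with thiophen-2-yl held constant, so neither change separates the compounds. No measured property bears on these results, so nothing can be said about what lies behind them.

Still open, as far as these compounds go, is whether a phenyl ring on the carbonyl carbon would give a step beyond the scatter. The same question stands for an amine in place of the chlorine on the chain.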